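The compounds below may be only part of what the source reports. "The series", "measured", "known", "first", "only" and "open" are said of these compounds alone.

Working notes on the series. In an ADME assay on HEK293 cells (Homo sapiens) for cytotoxicity, read by MTT assay, with a stated time of 48 h (on this read-out higher numbers stand for weaker inhibition and lower numbers for stronger inhibition), compound 1 `O=C1/C(=C\c2ccc(O)cc2)S/C(=N/c2ccccc2)N1Cc1ccncc1` gives 142000 nM and compound 2 `CC(C)c1ccc(/C=C2/S/C(=N/c3ccccc3)N(Cc3ccncc3)C2=O)cc1` gives 137000 nM while compound 3 `O=C1/C(=C\c2cccc(O)c2)S/C(=N/c2ccccc2)N1Cc1ccncc1` gives 150000 nM in the same range. Compound 3 thus stands level with the other two, since a 1.1-fold higher number from compound 1 to compound 3 (0.02 log units; within the scatter) and a 1.1-fold higher number from compound 2 to compound 3 (0.04 log units; within the scatter) do not separate it from either.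

The next structure is compound 4 `O=C1/C(=C\c2cccc(Cl)c2)S/C(=N/c2ccccc2)N1Cc1ccncc1` and it differs from compound 3 by chloro in place of hydroxy on an aromatic carbon in the exchange of 3-hydroxyphenyl to 3-chlorophenyl, which is chloro in place of hydroxy on an aromatic carbon.

Going by the values given here, two measured steps bear on this change. The removal of a hydroxy group is seen in a 1.0-fold lower number from compound 1 to compound 2 (0.02 log units; within the scatter) with isopropyl in place of hydroxy on an aromatic carbon. The relocation of the hydroxy group is seen in a 1.1-fold higher number from compound 1 to compound 3 (0.02 log units; within the scatter) on the same aromatic ring. Neither step leaves the scatter, so replacing or moving a hydroxy group has so far produced no measurable shift in this assay within these three compounds. Among the compounds with values here, no compound measured so far carries chloro, so that group remains untested here.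

The expected result is a 1.2-fold lower number from compound 3 to compound 4 (0.06 log units; within the scatter) as a step no larger than the scatter, with no direction anticipated. For compound 4 the estimated value is 130000 nM with an expected range from 75000 nM to 195000 nM on this read-out.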

Compound 4, half-maximal inhibitory concentration: 71800 nM
The estimate for compound 4 lay 1.8-fold (0.26 log units) above the measured number; measured number below the stated range.
By their numbers in this assay, from the lowest: compounds 4, 2, 1 and 3 (each within the scatter of the next, the first and the last beyond it).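

In this assay, going by these compounds alone, the position on the six-membered aromatic ring of carbon only, meta to a large group, responds to chloro in place of hydroxy with a 2.1-fold lower number from compound 3 to compound 4 (0.32 log units; beyond the scatter) and this modest step is the first printed as beyond the scatter. The wider exchanges, a 1.9-fold lower number from compound 2 to compound 4 (0.28 log units; within the scatter) and a 2.0-fold lower number from compound 1 to compound 4 (0.30 log units; within the scatter), both stay within the scatter, so compound 4 separates from compound 3 alone and not from compound 1 or compound 2. Nothing measured here accounts for the step from hydroxy to chloro.

As far as these compounds go, it remains open whether the step follows from the arrival of chloro or from the departure of hydroxy, a question that fluoro, methoxy or an amine at the same position could address. Within the data shown here, also open is whether chloro elsewhere on this ring, or a second chloro, would give a step of similar size against the hydroxy compounds, given that the present evidence rests on the single pair of compound 3 and compound 4.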